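The source may report more compounds than this note shows. Statements on the series, on what has been measured and on what is new or still open speak of the compounds shown alone.

Compound 1, `CNCC(=O)Nc1cc(OC)ccc1C(=O)c1ccc(OC)c2c1OC(C)(C)C=C2`, gives 740 nM.
Compound 2, `CNCC(=O)Nc1cc(OC)ccc1C(=O)c1ccc(OC)c2c1C=CC(C)(C)O2`, gives 3460 nM.
Compound 3, `CCNCC(=O)Nc1cc(OC)ccc1C(=O)c1ccc(OC)c2c1OC(C)(C)C=C2`, gives 3690 nM.

These three compounds were tested in a functional assay on HCT-8 cells (Homo sapiens) for antiproliferative activity, read by MTT assay, with a stated time of 48 h; a lower number here means a stronger inhibitor, a higher number a weaker inhibitor. Compound 1 stands lowest in this assay, at 740 nM. Compound 2 has the same atoms as compound 1 joined differently; the difference between the two cores is not broken down here. In this assay compound 2 gives 3460 nM, and compound 3 gives 3690 nM, so these two values fall within the usual scatter of each other. Compound 3 is related to compound 1 by one change, (methyl in place of hydrogen on a saturated chain carbon bound to an amine nitrogen), and that change made a step of a 5.0-fold higher number from compound 1 to compound 3 (0.70 log units; beyond the scatter).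

Compound 4, `CCNCC(=O)Nc1cc(OC)ccc1C(=O)c1ccc(OC)c2c1C=CC(C)(C)O2`, has not yet been measured in this assay. For the measured compounds named here, it is related to compound 2 by methyl in place of hydrogen on a saturated chain carbon bound to an amine nitrogen, which is the same change, at the same kind of place, as the one that separates compound 1 from compound 3. The account therefore has one earlier instance of this change to rest on. For compound 4 the expected step is a 4.3-fold higher number from compound 2 to compound 4 (0.64 log units; beyond the scatter), because the earlier instance of the same change gave a 5.0-fold higher number from compound 1 to compound 3 (0.70 log units; beyond the scatter). Going by the values given here, since only one such step is known, and it is of modest size, the expectation carries a wide range. Compound 4 is estimated to give about 15000 nM in this assay, with the expected range running from 5000 nM to 45000 nM.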

Compound 4, half-maximal inhibitory concentration: 7890 nM
The estimate for compound 4 lay 1.9-fold (0.28 log units) above the measured number; the measured number falls inside the stated range.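

In this assay, the change from methylamino to ethylamino moved the number in the same direction on the core of compound 2 as on the core of compound 1, giving a 2.3-fold higher number from compound 2 to compound 4 (0.36 log units; beyond the scatter). Set side by side, the two steps agree in direction and cannot be told apart in size: the same change on two cores in this assay, a 5.0-fold higher number (0.70 log units; beyond the scatter) from compound 1 to compound 3 and a 2.3-fold higher number (0.36 log units; beyond the scatter) from compound 2 to compound 4, 2.2-fold (0.34 log units) apart, within the scatter of two such steps

This shows that, for these two pairs, the change carried over from one core to the other in direction, and no difference in its size can be claimed, so the smaller step on the core of compound 2 should not be read as a real weakening of the effect. It does not show that the change would behave the same way on any other core, and with one pair per core and a single assay, it says nothing about why the number rises.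

The compounds shown leave open what a primary amine, a longer chain such as propylamino, or a branched one such as isopropylamino would give in this place on either core. Also open, on these data alone, is whether a cyclic amine such as pyrrolidine would follow the same direction.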